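A few compounds are considered here, and "the series" means these few. Any claim that something is new, unique, unknown or untested is made for them only; others in the source may bear on it.

Two measured compounds share one core. Compound 1 `CNC(=O)c1cccc(S(=O)(=O)c2ccccc2Cc2c3c(n(CC(=O)O)c2C)CCNC3=O)c1` carries a 3-(methylcarbamoyl)phenyl on its sulfonyl sulfur, and in a functional assay on CHO.K1 cells for antagonist activity at prostaglandin D2 receptor 2 (Homo sapiens), read by GTPgammaS binding, with a stated time of 1 h (a higher number here means a weaker inhibitor, a lower number a stronger inhibitor), compound 1 gives 240 nM. Compound 2 `Cc1c(Cc2ccccc2S(=O)(=O)c2ccc(Cl)cc2)c2c(n1CC(=O)O)CCNC2=O` carries a 4-chlorophenyl there instead, and in this assay compound 2 gives 8.5 nM. For the measured compounds named here, the single step between them, a 28-fold lower number from compound 1 to compound 2 (1.45 log units; beyond the scatter), is large, so compound 2 stands at the lower of the two numbers, well apart from compound 1.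

Compound 3 `CCS(=O)(=O)c1ccccc1Cc1c2c(n(CC(=O)O)c1C)CCNC2=O` changes the same position once more: ethyl in place of 4-chlorophenyl on a sulfonyl sulfur. Going by the values given here, the only step that bears on it is the one between compound 1 and compound 2, which shows that swapping the group on the sulfonyl sulfur can move the number a long way. Here the whole aromatic ring is taken away and only a short two-carbon chain remains, a larger cut than the earlier swap of one ring for another. Whether the number rises or falls cannot be read directly from one step, but the removal of the ring that sets compound 2 apart from compound 1 makes a higher number the more likely outcome. The expected step is a 12-fold higher number from compound 2 to compound 3 (1.07 log units; beyond the scatter), and compound 3 is estimated at 100 nM, within a range from 20 nM to 600 nM.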

Compound 3, half-maximal inhibitory concentration: 550 nM
Compound 3: middle estimate off by 5.5-fold (0.74 log units), on the low side; measured number inside the range.
By their numbers in this assay, from the lowest: compound 2; then compound 1; then compound 3.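

Swapping the 4-chlorophenyl on the sulfonyl sulfur for ethyl gives a 65-fold higher number from compound 2 to compound 3 (1.81 log units; beyond the scatter) in this assay and so undoes the low number of compound 2, which shows that this position does not accept just any small group in place of that ring. The other comparison adds a second point, since ethyl in place of 3-(methylcarbamoyl)phenyl gives only a 2.3-fold higher number from compound 1 to compound 3 (0.36 log units; beyond the scatter) and is a modest change, so an aromatic ring on the sulfonyl sulfur does not by itself bring the number down to that of compound 2; what the ring carries, and where, matters as well. The data shown contain no measurement that explains either step.

These compounds leave open how much of the low number of compound 2 comes from the chlorine and how much from the ring itself, a question that a plain phenyl on the sulfonyl sulfur would help to settle. They also leave open whether a longer chain such as butyl, or a saturated ring such as cyclohexyl, would behave like ethyl or like 4-chlorophenyl.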